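Aryl ether variation on the dioxane acid series

The compounds below may be only part of what the source reports. "The series", "measured", "known", "first", "only" and "open" are said of these compounds alone.

Of the compounds shown here, two have numbers so far. Compound 1 `O=C(O)CC/C=C\CC1COC(c2ccccc2Cl)OC1c1cccnc1` gives 48 nM in an assay for inhibition of Thromboxane-A synthase (Homo sapiens), using microsomes; on this read-out higher numbers stand for weaker inhibition and lower numbers for stronger inhibition. Compound 2 `CC(C)(Oc1ccc(F)cc1)C1OCC(C/C=C\CCC(=O)O)C(c2cccnc2)O1` gives 51 nM in this assay. Compound 2 thus has the higher of the two numbers, but its gap to compound 1 is within the scatter, so the two compounds cannot be told apart on these data, and neither can be called the stronger inhibitor.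

Compound 3 `CC(C)(Oc1ccccc1[N+](=O)[O-])C1OCC(C/C=C\CCC(=O)O)C(c2cccnc2)O1` is the next compound and has not yet been measured in this assay. It differs from compound 2 in one place: 2-nitrophenyl in place of 4-fluorophenyl on an oxygen on a saturated carbon. Within the data shown here, no measured pair separates an aryl change of this kind, so the direction of the step is not known from the data at hand. Given that compound 1 and compound 2 carry different aryl groups at this end of the core yet sit within the scatter of each other, no step beyond the scatter is expected for compound 3 in this assay, and the step from a 1.2-fold higher number from compound 2 to compound 3 (0.07 log units; within the scatter) is estimated to be small. The expected value for compound 3 is 60 nM, with a range from 20 nM to 180 nM.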

Compound 3, half-maximal inhibitory concentration: < 10 nM
Compound 3: only a limit was reported; the forecaster's own chance of this, stated with the estimate: 3%; middle value at least 6.0-fold (0.77 log units) away from the limit.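

Among these compounds, replacing 4-fluorophenyl with 2-nitrophenyl on an oxygen on a saturated carbon gives an at least 5.1-fold lower number from compound 2 to compound 3 (0.70 log units; beyond the scatter) in this assay, the first step that lies beyond the scatter. The aryl group at this place therefore moves the read-out, and the change goes towards stronger inhibition. The value of compound 3, < 10 nM, is a limit of the assay and not a number, so the step has a known minimum but no known full size: the limit of < 10 nM in this assay, at which 1 of the 3 values shown sits.

The step changes the substituent and its location on the phenyl ring together, and compounds 2 and 3 cannot separate these two contributions. On these data alone, it remains open whether a plain phenyl, or a phenyl ring carrying a nitrile or an amine, on this same oxygen would keep the stronger inhibition or whether it is specific to the 2-nitrophenyl group, and how far compound 3 lies beyond its limit.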